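Oxan-4-ylamino for oxan-4-yloxy on the aryl ring

The source may report more compounds than this note shows. Statements on the series, on what has been measured and on what is new or still open speak of the compounds shown alone.

Measured compounds:
Compound 1, `CC(C)Nc1ccc(-c2ccn3c(CC4CC4)nnc3c2C(F)(F)F)cc1Cl`: 3.89 nM
Compound 2, `FC(F)(F)c1c(-c2ccc(OC3CCOCC3)c(Cl)c2)ccn2c(CC3CC3)nnc12`: 5.25 nM

In an assay on cells for displacement of a labelled ligand from metabotropic glutamate receptor 2 (Homo sapiens), read by scintillation counting, with a stated time of 60 min (a lower number here means a stronger inhibitor, a higher number a weaker inhibitor), compound 1 gives 3.89 nM and compound 2 gives 5.25 nM. Compound 2 holds the higher of the two numbers, but the gap between them is a 1.3-fold higher number from compound 1 to compound 2 (0.13 log units; within the scatter), so the two values cannot be ordered.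

Compound 3, `FC(F)(F)c1c(-c2ccc(NC3CCOCC3)c(Cl)c2)ccn2c(CC3CC3)nnc12`, has not yet been measured in this assay. It differs from compound 2 by (oxan-4-yl)amino in place of (oxan-4-yl)oxy on an aromatic carbon. Going by the values given here, the one measured step that bears on this exchange is a 1.3-fold higher number from compound 1 to compound 2 (0.13 log units; within the scatter), where an amino-linked group replaced an oxygen-linked one at the same aromatic carbon without leaving the scatter. A nitrogen linker in place of the oxygen linker is therefore expected to change the number little, as a 1.3-fold lower number from compound 2 to compound 3 (0.10 log units; within the scatter), in no fixed direction. The estimate for compound 3 in this assay is 4.2 nM, with a range from 1.5 nM to 12 nM.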

Compound 3, inhibition constant: 5.01 nM
Estimate against measurement, compound 3: 1.2-fold (0.08 log units) below; the measured number falls inside the stated range.
By their numbers in this assay, from the lowest: compounds 1, 3 and 2 (each within the scatter of the next).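

In this assay the exchange of (oxan-4-yl)oxy for (oxan-4-yl)amino gives a 1.0-fold lower number from compound 2 to compound 3 (0.02 log units; within the scatter) and isolates the linking atom on the aromatic carbon with the oxan-4-yl ring held constant, which the earlier step could not do because it changed both the linking atom and the group it carried. With the nitrogen held constant, oxan-4-yl in place of isopropyl gives a 1.3-fold higher number from compound 1 to compound 3 (0.11 log units; within the scatter) and so also leaves the value within the scatter. No measurement is available to explain why neither exchange separates the compounds.

The compounds shown leave open whether a methylene linker at this aromatic carbon would also stay within the scatter. They also leave open what an amine on the oxan-4-yl ring would do.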